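The compounds below may be only part of what the source reports. "The series", "measured", "known", "first", "only" and "open" are said of these compounds alone.

Compound 1 `Cc1cc(C)cc(NN=C2CCC(C)n3c2ncc(C(=O)O)c3=O)c1` stands at the edge of what a functional assay on the whole organism with Rattus norvegicus as the target (a higher number here means that more compound is needed for the effect, a lower number that less compound is needed), can resolve: in this assay compound 1 gives > 320 umol/kg, which is a limit of the assay and not a number. Compound 1 thus sits at the limit of > 320 umol/kg in this assay, at which 1 of the 2 values shown sits. Among the compounds with values here, compound 2 `Cc1cc(C)c(NN=C2CCC(C)n3c2ncc(C(=O)O)c3=O)c(C)c1` is the only other measured member of the series, and in this assay compound 2 gives 320 umol/kg. Within the data shown here, no step between the two is given, so only the two values themselves can be read, and they say nothing of order.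

Compound 3 `CC1CCC(=NNc2cc(Cl)cc(Cl)c2)c2ncc(C(=O)O)c(=O)n21` has not yet been measured. It differs from compound 1 by 3,5-dichlorophenyl in place of 3,5-dimethylphenyl on an amine nitrogen. With compound 1 held at a limit, no step beyond the scatter is expected in either direction. The estimate for compound 3 in this assay is 320 umol/kg, with a range from 100 umol/kg to 1000 umol/kg. The expected step of a number no higher from compound 1 to compound 3 (the limit leaves the size open) is therefore taken as none beyond the scatter.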

Compound 3, dose for 50% inhibition: > 100 umol/kg
Compound 3: only a limit was reported; the forecaster's own chance of this, stated with the estimate: 60%; the middle value is on the limit's open side.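

In this assay compound 1 gives > 320 umol/kg, a limit of the assay. Compound 3 gives > 100 umol/kg, also a limit of the assay. Within the data shown here, no step between compound 1 and compound 3 can be read. Still open, on these data alone, is whether 3,5-dichlorophenyl in place of 3,5-dimethylphenyl on an amine nitrogen changes the dose needed at all.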